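The source may report more compounds than this note shows. Statements on the series, on what has been measured and on what is new or still open speak of the compounds shown alone.

Working notes on the series. Compound 1, `CC(=O)c1sc(NC(C)C)c(C#N)c1N`, gives only > 5000 nM in an assay for inhibition of Maternal embryonic leucine zipper kinase (Homo sapiens), read by ADP-Glo, with a stated time of 0.5 h; a lower number here means a stronger inhibitor, a higher number a weaker inhibitor; that value is a limit of the assay, not a number. Compound 2, `Cc1ccc(C(=O)c2sc(NC(C)C)c(C#N)c2N)s1`, gives 494 nM in this assay, the only number shown so far. The step of an at least 10-fold lower number from compound 1 to compound 2 (1.00 log units; beyond the scatter) is open-ended on one side because of the limit of > 5000 nM in this assay, at which 1 of the 2 values shown sits. Compound 3, `CC(C)Nc1sc(C(=O)c2cc(Br)cs2)c(N)c1C#N`, has not yet been measured. It differs from compound 2 by 4-bromothiophen-2-yl in place of 5-methylthiophen-2-yl on a carbonyl carbon. For the measured compounds named here, no measured step compares two different substituents on the thiophene attached to the carbonyl carbon; the only step measured replaced a methyl with the whole ring and does not speak to exchanging a methyl for a bromine within that ring. The expected change is therefore none beyond the scatter, a 1.0-fold higher number from compound 2 to compound 3 (0.01 log units; within the scatter). Compound 3 is estimated at 500 nM, between 200 nM and 1500 nM.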

Compound 3, half-maximal inhibitory concentration: 599 nM
Beside the measured number, compound 3's estimate is 1.2-fold (0.08 log units) below it, and the stated range covers the measured number.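

Exchanging 5-methylthiophen-2-yl for 4-bromothiophen-2-yl on a carbonyl carbon gives a 1.2-fold higher number from compound 2 to compound 3 (0.08 log units; within the scatter) in this assay, so the two rings cannot be told apart in this assay. The advantage over methyl at this position is therefore seen with two differently substituted thiophene rings rather than one, with an at least 8.3-fold lower number from compound 1 to compound 3 (0.92 log units; beyond the scatter). That step is open-ended on one side because compound 1 stands at a limit of the assay, not at a number: the limit of > 5000 nM in this assay, at which 1 of the 3 values shown sits.

As far as these compounds go, the exchange alters both the substituent and its place on the ring, so the separate contribution of each remains open. From the compounds shown here alone, it also remains open how this position would respond to a phenyl ring in place of the thiophene, or to an amine or a carboxylic acid on the ring.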